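The compounds below may be only part of what the source reports. "The series", "measured", "known", "first", "only" and "open" are said of these compounds alone.

Three compounds have been measured in a physicochemical assay for pharmacokinetics, read by LC-MS, in phosphate buffer, at pH 7.4, in the presence of a further agent that is not named here; a higher number here means that the compound lasts longer, a lower number that the compound disappears faster:

compound 1 `C=CC(=O)N1CC(NC(=O)Cn2c(C3CC3)c(C(=O)N3CCc4c(cccc4OC)C3)c3cc(Br)ccc32)C1` — 1.67 h
compound 2 `C=CC(=O)N1CC(NC(=O)Cn2c(C)c(C(=O)N3CCc4c(cccc4OC)C3)c3cc(Cl)ccc32)C1` — 1.67 h
compound 3 `C=CC(=O)N1CC(NC(=O)Cn2c(C)c(C(=O)N3CCc4c(cccc4OC)C3)c3cc(Br)ccc32)C1` — 1.67 h

Compound 2 stands level with compound 1 and compound 3 at the digits shown. The two measured steps confirm this: no change at the digits printed from compound 1 to compound 3 (within the scatter) and no change at the digits printed from compound 2 to compound 3 (within the scatter). In other words, swapping the group on one aromatic carbon of the shared core, or swapping the halogen on another, has so far left the half-life where it was.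

Compound 4 `C=CC(=O)N1CC(NC(=O)Cn2c(C)c(C(=O)N3CCc4c(cccc4OC)C3)c3cc(Cl)cc(C)c32)C1` is the next compound to be tested in this assay. It differs from compound 2 in one place: methyl in place of hydrogen on an aromatic carbon. Going by the values given here, no measured pair adds a methyl to a ring hydrogen at this position, so the estimate rests only on the general picture that small changes on the aromatic part of the core have not moved the half-life. The step from compound 2 to compound 4 is therefore expected to be no change at the digits printed from compound 2 to compound 4 (within the scatter), that is, no change beyond the scatter. The estimated value for compound 4 is 1.67 h, with a range from 0.8 h to 3.4 h.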

Compound 4, half-life: 1.67 h
Compound 4: the middle estimate sits on the measured number at the digits printed; the range from low to high includes it.
By their numbers in this assay, from the lowest: compounds 1, 2, 3 and 4 (each within the scatter of the next).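

The half-life read in this assay shows no change at the digits printed from compound 2 to compound 4 (within the scatter) when a methyl replaces hydrogen on the aromatic carbon ortho to a fused ring and meta to a chloro group. The earlier steps shown here only exchanged one group for another at two other places, whereas this step adds a group where there was only hydrogen, at a third place on the shared core. No measurement here accounts for this steady half-life.

The compounds shown leave open whether the half-life would hold with something other than methyl at this position, such as an amine, a carboxylic acid or a longer chain. They also leave open whether changes elsewhere would move it, since all four compounds share the rest of their structure.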